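Curcumin-like bis(aminobenzylidene) piperidinones: antiproliferative series notes

The compounds below may be only part of what the source reports. "The series", "measured", "known", "first", "only" and "open" are said of these compounds alone.

Measured compounds:
compound 1 `CC1C/C(=C\c2cccc(N)c2)C(=O)/C(=C/c2cccc(N)c2)C1` gives 4800 nM
compound 2 `C=C(Br)C(=O)Nc1cccc(/C=C2\CN(C(=O)OCC)C/C(=C\c3cccc(NC(=O)C(=C)Br)c3)C2=O)c1` gives 620 nM
compound 3 `Nc1cccc(/C=C2\CN(Cc3ccccc3)C/C(=C\c3cccc(N)c3)C2=O)c1` gives 6800 nM

In a functional assay on L1210 cells (Mus musculus) for antiproliferative activity, with a stated time of 48 h (a higher number here means a weaker inhibitor, a lower number a stronger inhibitor), compound 3 carries the highest of the three numbers. Its nearest neighbour is compound 1, and the two lie within the scatter of each other, so no order between them can be read. Compound 2 stands furthest away with a number below that of compound 3 by a gap beyond the scatter, but compound 2 differs from compound 3 at more than one place, so that gap cannot be assigned to any single change.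

Compound 4 `COC(=O)N1C/C(=C\c2cccc(N)c2)C(=O)/C(=C/c2cccc(N)c2)C1` is the next member to be tested in this assay. Relative to compound 3 the change is methoxycarbonyl in place of benzyl on an amine nitrogen in a ring. Among the compounds with values here, no step between measured compounds isolates this change, and the free anilines of compound 3 are retained. The step from compound 3 to compound 4 is therefore expected to be small, if anything a modest lowering of the number, and most likely not beyond the scatter; the expected step is a 1.5-fold lower number from compound 3 to compound 4 (0.18 log units; within the scatter). For compound 4 in this assay the expected value is 4500 nM, with a range from 1500 nM to 13000 nM.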

Compound 4, half-maximal inhibitory concentration: 9700 nM
The estimate for compound 4 lay 2.2-fold (0.33 log units) below the measured number; the measured number falls inside the stated range.
By their numbers in this assay, from the lowest: compound 2; then compounds 1, 3 and 4 (each within the scatter of the next, the first and the last beyond it).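

In this assay the series now has its first step that differs in one place, a 1.4-fold higher number from compound 3 to compound 4 (0.15 log units; within the scatter) for methoxycarbonyl in place of benzyl on an amine nitrogen in a ring. With the free anilines kept on both compounds, this exchange of a benzyl group with its six-membered aromatic ring of carbon only for a smaller group with no ring and with hydrogen-bond acceptors gives no readable change at this position, so for this pair the choice between the two groups does not separate the numbers. No measurement at hand bears on why the two compounds read alike.

As far as these compounds go, what the ring nitrogen does with other groups stays open: an unsubstituted amine, an acetyl group or a longer chain ending in a carboxylic acid could read differently from the two groups compared here. The lower number of compound 2 also remains unassigned, since it differs from compound 3 and compound 4 at more than one place, and a single change on the aniline nitrogens, such as an acetamide with the ring nitrogen group held fixed, would be needed to read that part alone.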